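This account rests on a few compounds, and the source may have more. Where it says the series, first, only, none or still open, it means among the compounds named here.

Compound 2 `O=c1ccc(-c2ccc3cn[nH]c3c2)cn1Cc1ccccc1` is the only one of the three measured compounds for which an assay for inhibition of MAP kinase-interacting serine/threonine-protein kinase 2 (Homo sapiens), read by luminescence and ADP-Glo, with a stated time of 2 h (on this read-out lower numbers stand for stronger inhibition and higher numbers for weaker inhibition), gives a number: in this assay compound 2 gives 75 nM. For compound 1 `Cn1ncc2ccc(-c3ccc(=O)n(Cc4ccccc4)c3)cc21` this assay reports only a limit, > 2000 nM. For compound 3 `NC(=O)c1ccc(Cn2cc(-c3ccc4cn[nH]c4c3)ccc2=O)cc1` this assay likewise reports only a limit, > 2000 nM. Both measured steps are therefore large and bounded by the limit of this assay the limit of > 2000 nM in this assay, at which 2 of the 3 values shown sit: an at least 26-fold lower number from compound 1 to compound 2 (1.42 log units; beyond the scatter), and an at least 26-fold higher number from compound 2 to compound 3 (1.42 log units; beyond the scatter).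

Compound 4 `O=c1ccc(-c2ccc3cn[nH]c3c2)cn1Cc1ccc(Cl)c(Cl)c1` differs from compound 2 by 3,4-dichlorophenyl in place of phenyl on a saturated chain carbon bound to an aromatic nitrogen. The step from compound 1 to compound 2 changes the aromatic nitrogen, not this phenyl, so it says nothing about compound 4. The step from compound 2 to compound 3 does alter the same phenyl, with a carbamoyl, and was large toward weaker inhibition; the two chlorines are a different group, so that step sets no firm size. A modest step is expected, a 2.0-fold higher number from compound 2 to compound 4 (0.30 log units; within the scatter). Compound 4 is estimated at 150 nM, with a range from 40 nM to 700 nM.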

Compound 4, half-maximal inhibitory concentration: 97 nM
For compound 4 the middle estimate is 1.5-fold (0.19 log units) above the measured one; low and high end bracket the measured number.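

In this assay, adding two chlorines to the phenyl on the saturated chain carbon gives a 1.3-fold higher number from compound 2 to compound 4 (0.11 log units; within the scatter). Within the data shown here, the phenyl at this place can therefore carry 3,4-dichlorophenyl substitution with no change beyond the scatter, something the earlier compounds did not show. The large step to weaker inhibition seen with the carbamoyl, an at least 26-fold higher number from compound 2 to compound 3 (1.42 log units; beyond the scatter), is thus not shared by every group added to this ring, with compound 3 going against compound 4 here.

The compounds shown leave open whether a phenyl with a single chlorine, or one carrying an amine or a carboxylic acid, would follow compound 4 or compound 3. How much weaker compound 3 really is also stays unknown, as its value is only a limit: the limit of > 2000 nM in this assay, at which 2 of the 4 values shown sit.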